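The compounds below may be only part of what the source reports. "The series", "measured", "known", "first", "only" and "open" are said of these compounds alone.

Measured compounds:
compound 1 `CC(=O)OC[C@H]1O[C@@H](n2cc(CN3C(=O)/C(=C/c4ccccc4)c4ccccc43)nn2)[C@H](OC(C)=O)[C@@H](OC(C)=O)[C@@H]1OC(C)=O` — 22800 nM
compound 2 `CC(=O)OC[C@H]1O[C@@H](n2cc(CN3C(=O)/C(=C/C=C/c4ccccc4)c4ccccc43)nn2)[C@H](OC(C)=O)[C@@H](OC(C)=O)[C@@H]1OC(C)=O` — 17100 nM
compound 3 `CC(=O)OC[C@H]1O[C@@H](n2cc(CN3C(=O)/C(=C/c4ccc5ccccc5c4)c4ccccc43)nn2)[C@H](OC(C)=O)[C@@H](OC(C)=O)[C@@H]1OC(C)=O` — 43700 nM

In a functional assay on DU-145 cells (Homo sapiens) for cytotoxicity, read by sulforhodamine B assay, with a stated time of 48 h (on this read-out lower numbers stand for stronger inhibition and higher numbers for weaker inhibition), compound 3 gives the highest number of the three, although its gap to compound 1 lies within the scatter, a 1.9-fold higher number from compound 1 to compound 3 (0.28 log units; within the scatter); only its gap to compound 2 lies beyond it, a 2.6-fold higher number from compound 2 to compound 3 (0.41 log units; beyond the scatter). Compound 4 `CC(=O)OC[C@H]1O[C@@H](n2cc(CN3C(=O)/C(=C/c4ccco4)c4ccccc43)nn2)[C@H](OC(C)=O)[C@@H](OC(C)=O)[C@@H]1OC(C)=O` differs from compound 3 in one place: furan-2-yl in place of naphthalen-2-yl on a double-bonded chain carbon bound to a double-bonded ring carbon. Among the compounds with values here, no measured step involves furan-2-yl. Within the data shown here, the steps that bear on the change are those in which naphthalen-2-yl entered in place of a smaller group, one within and one modestly beyond the scatter. Returning to a smaller aromatic group is therefore expected to give a small step downward or none beyond the scatter, a 1.7-fold lower number from compound 3 to compound 4 (0.23 log units; within the scatter). Compound 4 is estimated at 26000 nM, within 10000 nM to 65000 nM.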

Compound 4, half-maximal inhibitory concentration: 10000 nM
For compound 4 the middle estimate is 2.6-fold (0.41 log units) above the measured one; the range from low to high includes it.
By their numbers in this assay, from the lowest: compounds 4, 2, 1 and 3 (each within the scatter of the next, the first and the last beyond it).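

In this assay, furan-2-yl on a double-bonded chain carbon bound to a double-bonded ring carbon gives a step beyond the scatter against both naphthalen-2-yl (a 4.4-fold lower number from compound 3 to compound 4 (0.64 log units; beyond the scatter)) and phenyl (a 2.3-fold lower number from compound 1 to compound 4 (0.36 log units; beyond the scatter)), while its gap to 2-phenylethenyl stays within the scatter (a 1.7-fold lower number from compound 2 to compound 4 (0.23 log units; within the scatter)). Within the data shown here, this is the first group at this place with a hetero atom, and it separates from phenyl as no earlier group did. Nothing measured here explains the change. The compounds shown leave open whether thiophen-2-yl or pyridin-2-yl would match furan-2-yl, or whether an amine on the ring would shift the value.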